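Side-chain change on the aromatic ring of compound 1

A few compounds are considered here, and "the series" means these few. Any claim that something is new, unique, unknown or untested is made for them only; others in the source may bear on it.

- compound 1 `CCN(CC)CCNC(=O)C1CC(C(CC)(CC)c2ccc(C#CC(O)C3CCC3)c(C)c2)=CN1CC` gives 1280 nM
- compound 2 `CCCC(O)(C#Cc1ccc(C(CC)(CC)C2=CCC(C(=O)NCCN(CC)CC)N2CC)cc1C)CCC` gives 1360 nM

In a functional assay on MCF7 cells (Homo sapiens) for antiproliferative activity, read by MTT assay, with a stated time of 24 h (on this read-out lower numbers stand for stronger inhibition and higher numbers for weaker inhibition), compound 1 and compound 2 lie within the usual scatter of each other, so compound 1 stands level with compound 2 and the two numbers show no order. Compound 3 `CCN(CC)CCNC(=O)C1CC(C(CC)(CC)c2ccc(CCC(O)(CC)CC)c(C)c2)=CN1CC` has not yet been measured in this assay. It keeps the core of compound 1 and changes one group on an aromatic carbon, ortho to a methyl group and para to a large group: a group of 8 heavy atoms (7 carbon, 1 oxygen; no ring) in place of a group of 8 heavy atoms (7 carbon, 1 oxygen; one four-membered non-aromatic ring of carbon only), on an aromatic carbon. The entering 3-ethyl-3-hydroxypentyl has no ring and no triple bond. For the measured compounds named here, no measured pair isolates this change, so the expectation rests on thin evidence: the side chains of compound 1 and compound 2 differ, yet compound 2 gives 1360 nM. The expected 1.2-fold higher number from compound 1 to compound 3 (0.07 log units; within the scatter) is small, with no shift beyond the scatter in this assay. Compound 3 is estimated at 1500 nM, with an expected range of 600 nM to 4000 nM.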

Compound 3, half-maximal inhibitory concentration: 3580 nM
Compound 3: the middle estimate sits 2.4-fold (0.38 log units) below what was measured; the measured number falls inside the stated range.
By their numbers in this assay, from the lowest: compounds 1 and 2 (each within the scatter of the next); then compound 3.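

In this assay the aromatic carbon ortho to a methyl group and para to a large group is sensitive to the side chain it carries, with a 2.8-fold higher number from compound 1 to compound 3 (0.45 log units; beyond the scatter) as a modest step beyond the scatter. The leaving group and 3-ethyl-3-hydroxypentyl match in heavy atoms, hydrogen-bond donors and acceptors, so the step goes with a difference in shape of the chain: the four-membered ring and the triple bond both leave. Nothing at hand gives a reason for the step.

The ring and the triple bond leave together, so the compounds shown leave open which of the two the step follows. Also open, going by these compounds, is how an amine in place of the hydroxy group on this side chain would read at this position.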